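Extending the ring nitrogen substituent of a benzamide agonist

A few compounds are considered here, and "the series" means these few. Any claim that something is new, unique, unknown or untested is made for them only; others in the source may bear on it.

Measured so far:
Compound 1, `COc1cc(N)c(Cl)cc1C(=O)NCC1CCNCC1`: 398 nM
Compound 2, `CC(C)n1c(=O)n(C(=O)NCCN2CCNCC2)c2ccccc21`: 7.94 nM
Compound 3, `CCN1CCC(NC(=O)c2cc(Cl)c(N)cc2OC)CC1`: 79.4 nM

All three were tested in a functional assay on HEK293 cells for agonist activity at 5-hydroxytryptamine receptor 4 (Homo sapiens), read by cAMP accumulation; a lower number here means that less compound is needed, a higher number that more compound is needed for the effect. Among these numbers compound 3 stands second highest: compound 1 gives a higher number, beyond the scatter, while compound 2 gives a lower number, also beyond the scatter.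

Compound 4, `COc1cc(N)c(Cl)cc1C(=O)NC1CCN(CCCCCCCCO)CC1`, differs from compound 3 in one place: 6-hydroxyhexyl in place of hydrogen on a saturated chain carbon, two bonds along the chain from an amine nitrogen in a ring. Read one bond further out, the change is ethyl to 8-hydroxyoctyl on the ring nitrogen.

Within the data shown here, no measured pair shows this kind of change, so the expectation rests on the general picture. The step of a 2.0-fold lower number from compound 3 to compound 4 (0.30 log units; within the scatter) is expected to be modest, toward a lower number, though it may also fall within the scatter. Compound 4 is therefore estimated at 40 nM, with a range from 8 nM to 200 nM.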

Compound 4, half-maximal effective concentration: 15.9 nM
Compound 4: middle estimate off by 2.5-fold (0.40 log units), on the high side, within the range that was stated.
By their numbers in this assay, from the lowest: compounds 2 and 4 (each within the scatter of the next); then compound 3; then compound 1.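

On the ring nitrogen, replacing ethyl with 8-hydroxyoctyl gives a 5.0-fold lower number from compound 3 to compound 4 (0.70 log units; beyond the scatter) in this assay. This first single-place comparison in the series shows that this position accepts a much longer chain carrying a hydroxyl group, with no loss of agonist potency. No available measurement explains the size of this step.

Going by these compounds, it remains open whether the chain length, the hydroxyl group, or both account for the change. A plain octyl chain, a shorter hydroxyalkyl chain, or an amine or carboxylic acid in place of the hydroxyl would help separate these contributions.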